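The compounds below may be only part of what the source reports. "The series", "measured", "known", "first", "only" and "open" are said of these compounds alone.

Measured so far:
Compound 1 `CCN(CC)S(=O)(=O)c1ccc(S(=O)(=O)N2CCC[C@@H](C(=O)NC3COC3)C2)cc1` — in a functional assay on BXPC-3 cells (Homo sapiens) for inhibition, read by MTT assay, with a stated time of 7 days (a lower number here means a stronger inhibitor, a higher number a weaker inhibitor), compound 1 gives 13800 nM.
Compound 2 `CCN(CC)S(=O)(=O)c1ccc(S(=O)(=O)N2CCC[C@@H](C(=O)NC3CN(C(=O)NC(C)(C)C)C3)C2)cc1` — in this assay compound 2 gives 10100 nM.

Among the compounds with values here, compound 2 has the lowest of the two numbers, but its only neighbour, compound 1, sits within the usual scatter: a 1.4-fold lower number from compound 1 to compound 2 (0.14 log units; within the scatter). Compound 3 `CCN(CC)S(=O)(=O)c1ccc(S(=O)(=O)N2CCC[C@@H](C(=O)N[C@H]3CCN(C(=O)OC(C)(C)C)C3)C2)cc1` is the next step; its difference from compound 2 is 1-(tert-butoxycarbonyl)pyrrolidin-3-yl in place of 1-((tert-butyl)carbamoyl)azetidin-3-yl on an amide-type nitrogen. Within the data shown here, no measured step tests this change directly, and the one step in this assay stayed within the scatter, so compound 3 is expected to stay close: a 1.0-fold lower number from compound 2 to compound 3 (0.00 log units; within the scatter). The estimate for compound 3 is therefore 10000 nM, with a range from 4000 nM to 25000 nM.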

Compound 3, half-maximal inhibitory concentration: 300 nM
Compound 3: the middle estimate sits 33-fold (1.52 log units) above what was measured; measured number below the stated range.
By their numbers in this assay, from the lowest: compound 3; then compounds 2 and 1 (each within the scatter of the next).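

In this assay, the group on the amide-type nitrogen proves able to move the number far beyond the scatter, with a 34-fold lower number from compound 2 to compound 3 (1.53 log units; beyond the scatter) and a 46-fold lower number from compound 1 to compound 3 (1.66 log units; beyond the scatter) standing against the earlier step that stayed within it. This change swaps a four-membered ring for a five-membered one and also replaces the tert-butyl carbamoyl with tert-butoxycarbonyl, so the step cannot separate the two. Nothing available explains the gain. Open, going by these compounds, is whether a free amine or an acetyl group could replace the tert-butoxycarbonyl, and whether the opposite stereocentre would hold the number.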